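The source may report more compounds than this note shows. Statements on the series, on what has been measured and on what is new or still open speak of the compounds shown alone.

The numbers below come from an assay on HEK293 cells for displacement of a labelled ligand from Melanocortin receptor 4 (Homo sapiens); a higher number here means a weaker inhibitor, a lower number a stronger inhibitor.

Compound 1, `Cc1cc(Cl)ccc1CC(C)C(=O)N1CCN(c2ccc(C(F)(F)F)cc2[C@@H](N)CC(C)C)CC1`: 38 nM
Compound 2, `CC(C)C[C@H](N)c1cc(C(F)(F)F)ccc1N1CCN(C(=O)CNc2ccccc2)CC1`: 3600 nM
Compound 3, `CC(C)C[C@H](N)c1cc(C(F)(F)F)ccc1N1CCN(C(=O)C(C)Cc2ccc(Cl)cc2O)CC1`: 36 nM

Among these three, compound 1 stands second highest: compound 3 is nearest, with a 1.1-fold lower number from compound 1 to compound 3 (0.02 log units; within the scatter), and compound 2 is furthest, with a 95-fold higher number from compound 1 to compound 2 (1.98 log units; beyond the scatter). Compound 4, `CC(C)C[C@H](N)c1cc(C(F)(F)F)ccc1N1CCN(C(=O)CSc2ccc(Cl)cc2Cl)CC1`, has not been measured. It differs from compound 1 in one place: ((2,4-dichlorophenyl)sulfanyl)methyl in place of 1-(4-chloro-2-methylbenzyl)ethyl on a carbonyl carbon.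

Going by the values given here, two measured steps bear on this. The step of a 95-fold higher number from compound 1 to compound 2 (1.98 log units; beyond the scatter) swapped the same group on the same carbonyl carbon for anilinomethyl, a group with a single-atom link between the carbonyl carbon and an aromatic ring, and the number rose a great deal; the step of a 100-fold lower number from compound 2 to compound 3 (2.00 log units; beyond the scatter) reversed that kind of change and brought the number back down. Compound 4 likewise carries a single-atom link from that carbonyl carbon to an aromatic ring, here through sulfur, and loses the branching methyl, though its ring keeps chlorine. A rise in the number is therefore expected, smaller than in those two steps because the step of a 95-fold higher number from compound 1 to compound 2 (1.98 log units; beyond the scatter) also removed chlorine, while compound 4 retains it. The expected step is a 6.6-fold higher number from compound 1 to compound 4 (0.82 log units; beyond the scatter). For compound 4 the estimate in this assay is 250 nM, with a range from 50 nM to 1500 nM.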

Compound 4, inhibition constant: 1500 nM
Beside the measured number, compound 4's estimate is 6.0-fold (0.78 log units) below it, within the range that was stated.
By their numbers in this assay, from the lowest: compounds 3 and 1 (each within the scatter of the next); then compound 4; then compound 2.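

In this assay placing ((2,4-dichlorophenyl)sulfanyl)methyl on this carbonyl carbon gives a 39-fold higher number from compound 1 to compound 4 (1.60 log units; beyond the scatter) and a 42-fold higher number from compound 3 to compound 4 (1.62 log units; beyond the scatter) so two chlorines on the ring do not by themselves keep the number low. Set against the anilino group, (2,4-dichlorophenyl)sulfanyl gives only a 2.4-fold lower number from compound 2 to compound 4 (0.38 log units; beyond the scatter) and so the low numbers of this set stay with the two branched groups, those of compound 1 and compound 3. Nothing measured here explains these steps.

The new group differs from the branched ones in several features at once, so the compounds shown cannot separate the effect of the sulfur from that of the lost branching methyl. A close analogue with an ether oxygen or a methylene link in place of the sulfur, or with a methyl branch on the chain, would still have to be compared.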